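The source may hold more compounds than are shown below. What is called first, only, known or untested is meant among the compounds shown, and "the series" means these compounds.

Compound 1 `CCCCC1([C@H](O)/C=C/C2CCC(=O)[C@@H]2CCCCSCC(=O)OCC)CCC1`: 0.03 mg/kg
Compound 2 `CCCCC1([C@@H](O)/C=C/C2CCC(=O)[C@@H]2CCCCSCC(=O)O)CCC1`: 0.606 mg/kg

In a functional assay on the whole organism (strain Hartley) for inhibition, with Cavia porcellus as the target, with stated times of 15 min and 2 min (on this read-out higher numbers stand for an effect only at larger amounts of compound and lower numbers for an effect already at smaller amounts), compound 2, at 0.606 mg/kg, holds the higher of the two numbers, and compound 1, at 0.03 mg/kg, lies lower, beyond the scatter. Compound 3 `CCCCC1([C@H](O)/C=C/C2CCC(=O)[C@@H]2CCCCSCC(=O)O)CCC1` differs from compound 2 as follows: the two compounds have the same atoms and bonds; at least one stereo element is drawn with a configuration in one of them and without one in the other: 1 of 4 stereo elements differ; a stereocentre at a saturated chain carbon is drawn S in compound 2 and R in compound 3. Within the data shown here, no measured step of this kind exists here, so the size is uncertain. Compound 1, also drawn R at that carbon, gives 0.03 mg/kg, so a moderate move towards lower numbers is expected in this assay, not a null step. The expected change is a 5.1-fold lower number from compound 2 to compound 3 (0.70 log units; beyond the scatter). The estimated value for compound 3 is 0.12 mg/kg, with an expected range of 0.025 mg/kg to 0.6 mg/kg.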

Compound 3, dose for half-maximal effect: 0.0912 mg/kg
Beside the measured number, compound 3's estimate is 1.3-fold (0.12 log units) above it, and the stated range covers the measured number.
By their numbers in this assay, from the lowest: compound 1; then compound 3; then compound 2.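

In this assay the stereocentre at a saturated chain carbon is the one place of difference: with atoms and bonds unchanged, S to R gives a 6.6-fold lower number from compound 2 to compound 3 (0.82 log units; beyond the scatter). With R held, the ester can now be read alone: hydrogen in place of ethyl gives a 3.0-fold higher number from compound 1 to compound 3 (0.48 log units; beyond the scatter). The stereo step is read with one caveat on the drawings: the fact that one of compounds 2 and 3 is drawn with a defined configuration and the other without, at the place where they differ

Open, from the compounds shown here alone, is whether the ester effect holds with S at that carbon. Also open, going by these compounds, is how a methyl ester or a primary amide compares with the ethyl ester.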